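This account rests on a few compounds, and the source may have more. Where it says the series, first, only, none or still open, it means among the compounds named here.

In a functional assay, read by Griess assay, with a stated time of 2.5 h (on this read-out higher numbers stand for weaker inhibition and lower numbers for stronger inhibition), compound 1 (`COc1cc(OC)c(OC)cc1/C=C/C(=O)c1cc(Cc2ccccc2)cc(Cc2ccccc2)c1`) gives 2.09 ug/mL and compound 2 (`COc1cc(OC)c(OC)cc1/C=C/C(=O)c1ccc(O)cc1O`) gives 2.76 ug/mL as its number. These two values lie within the usual scatter of each other, so compound 2 stands level with compound 1 on the evidence so far. Compound 3 (`COc1cc(OC)c(OC)cc1/C=C/C(=O)c1cc(O)ccc1O`) has the same atoms as compound 2, joined differently, with 2,5-dihydroxyphenyl in place of 2,4-dihydroxyphenyl on a carbonyl carbon. Going by the values given here, no pair of measured compounds shows what a change of this kind does in this assay here, so compound 2 at 2.76 ug/mL serves as the only close starting point. The expectation is a step of a 1.1-fold lower number from compound 2 to compound 3 (0.04 log units; within the scatter) that stays within the scatter, with no firm direction. For compound 3 the estimated value is 2.5 ug/mL with an expected range from 1 ug/mL to 6 ug/mL in this measurement.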

Compound 3, half-maximal inhibitory concentration: 2.44 ug/mL
The estimate for compound 3 lay 1.0-fold (0.01 log units) above the measured number; the range from low to high includes it.
By their numbers in this assay, from the lowest: compounds 1, 3 and 2 (each within the scatter of the next).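

Swapping 2,4-dihydroxyphenyl for 2,5-dihydroxyphenyl on a carbonyl carbon gives the first step in this assay that can be read between two compounds differing in one place: a 1.1-fold lower number from compound 2 to compound 3 (0.05 log units; within the scatter). Compounds 2 and 3 therefore cannot be told apart in this assay, so at this position, the rearrangement of the two hydroxyl groups between these two patterns leaves no effect that can be distinguished from the scatter. Nothing available here bears on why these two compounds read alike.

The compounds shown leave open whether a single hydroxyl group on this ring would read the same as the two hydroxyl groups do here. They also leave open what an amine or a carboxylic acid on this ring would do to the number.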